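The compounds below may be only part of what the source reports. "The series", "measured", "known", "first", "only" and "open" are said of these compounds alone.

Working notes on the series.

Compound 1 `CCCOC(=O)CC1C(C(=O)OCCC)=C(N)Oc2ccc(-c3cc(OC)cc(OC)c3)cc21` carries the core with two propyl esters and a dimethoxyphenyl ring; in a functional assay on HL-60 cells (Homo sapiens) for cytotoxicity, read by CellTiter-Blue, with a stated time of 48 h (a lower number here means a stronger inhibitor, a higher number a weaker inhibitor), compound 1 gives 7600 nM. Compound 2 `CCOC(=O)CC1C(C(=O)OCC)=C(N)Oc2ccc(-c3cccs3)cc21` has the ethyl esters and a thiophen-2-yl group. In this assay compound 2 gives > 80000 nM, which is a limit of the assay and not a number; compound 2 sits at the limit of > 80000 nM in this assay, at which 1 of the 2 values shown sits, so its true potency is not known beyond that. Compound 3 `CCOC(=O)CC1C(C(=O)OCC)=C(N)Oc2ccc(-c3cccc(C(N)=O)c3)cc21` is the next member to be measured. Compared with compound 2 the change is 3-carbamoylphenyl in place of thiophen-2-yl on an aromatic carbon. No measured step connects two compounds here, so the size of this one cannot be drawn from the numbers shown. Compound 3 is expected to move toward stronger inhibition, with a step of about an at least 2.6-fold lower number from compound 2 to compound 3 (0.42 log units; beyond the scatter), though a result at the limit again would not be surprising. Compound 3 is estimated at 30000 nM, in the range 8000 nM to 80000 nM.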

Compound 3, half-maximal inhibitory concentration: 5400 nM
For compound 3 the middle estimate is 5.6-fold (0.74 log units) above the measured one; measured number below the stated range.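

In this assay, the change to 3-carbamoylphenyl from thiophen-2-yl on this aromatic carbon gives an at least 14-fold lower number from compound 2 to compound 3 (1.17 log units; beyond the scatter). Among the compounds shown here, this is the first measured step, and it shows that, with the ethyl esters held constant, the group at this position alone can bring the read-out from the limit to a measurable value. The true size of the step stays open, as the value of compound 2 is a limit of the assay and not a number: the limit of > 80000 nM in this assay, at which 1 of the 3 values shown sits.

The change swaps the ring and adds the carbamoyl group at once, so the compounds shown do not separate the contribution of each. An unsubstituted phenyl ring, or a carboxylic acid in place of the carbamoyl group, would be needed to tell these apart.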